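A few compounds are considered here, and "the series" means these few. Any claim that something is new, unique, unknown or untested is made for them only; others in the source may bear on it.

Going by the values given here, compound 2 `COc1ccc(-n2cc(CN3C(=O)C[C@@H]4CC[C@@]3(C)C4(C)C)nn2)cc1` gives 330 nM in a functional assay on PANC-1 cells (Homo sapiens) for inhibition, read by MTT assay, with a stated time of 24 h (a lower number here means a stronger inhibitor, a higher number a weaker inhibitor), the highest of the three numbers measured so far; compound 1 `CC1(C)[C@H]2CC[C@]1(C)N(Cc1cn(-c3cccc(Cl)c3)nn1)C(=O)C2` gives 260 nM, which lies within the scatter of it, and compound 3 `CC1(C)[C@H]2CC[C@]1(C)N(Cc1cn(-c3ccc(F)cc3)nn1)C(=O)C2` gives 110 nM. The steps that reach compound 3 are a 3.0-fold lower number from compound 2 to compound 3 (0.48 log units; beyond the scatter) and a 2.4-fold lower number from compound 1 to compound 3 (0.37 log units; beyond the scatter), whereas a 1.3-fold higher number from compound 1 to compound 2 (0.10 log units; within the scatter). Compound 4 `CC1(C)[C@H]2CC[C@]1(C)N(Cc1cn(-c3ccccc3F)nn1)C(=O)C2` carries 2-fluorophenyl in place of 4-methoxyphenyl on an aromatic nitrogen. Among the compounds with values here, the step to compound 3 bears most closely on this change, both of them exchanging a methoxy for a fluoro, but no measured compound carries the 2-fluorophenyl itself. A modest lowering is therefore expected, a 1.7-fold lower number from compound 2 to compound 4 (0.22 log units; within the scatter), with a real chance that it stays within the scatter. For compound 4 the estimate is 200 nM, ranging from 80 nM to 500 nM.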

Compound 4, half-maximal inhibitory concentration: 150 nM
Estimate against measurement, compound 4: 1.3-fold (0.12 log units) above, within the range that was stated.
By their numbers in this assay, from the lowest: compounds 3, 4, 1 and 2 (each within the scatter of the next, the first and the last beyond it).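

In this assay the 2-fluorophenyl, like the 4-fluorophenyl before it, lies beyond the scatter from the 4-methoxyphenyl (a 2.2-fold lower number from compound 2 to compound 4 (0.34 log units; beyond the scatter)), so this lowering is not confined to one fluorophenyl. The two fluorophenyl compounds cannot be told apart (a 1.4-fold higher number from compound 3 to compound 4 (0.13 log units; within the scatter)). Unlike compound 3, compound 4 also stays within the scatter of the 3-chlorophenyl compound (a 1.7-fold lower number from compound 1 to compound 4 (0.24 log units; within the scatter)). The compounds shown leave open how an unsubstituted phenyl or a pyridyl ring would compare, and so whether the fluoro itself matters or only the absence of the methoxy. Nothing shown explains these differences.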